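A Chloro-to-Nitro Swap and Its Expected Effect on Lipophilicity

The source may report more compounds than this note shows. Statements on the series, on what has been measured and on what is new or still open speak of the compounds shown alone.

Measured so far:
Compound 1, `C/C(=N\NC(=O)COc1cccc2ccccc12)c1ccc([N+](=O)[O-])cc1` — 3.37
Compound 2, `C/C(=N\NC(=O)COc1cccc2ccccc12)c1ccc(Cl)cc1` — 4.17
Compound 3, `O=C(COc1cccc2ccccc12)N/N=C/c1ccccc1Cl` — 4.54

Of the compounds shown here, three have been measured in a physicochemical assay for lipophilicity, measured as octanol-water partition; on this read-out higher numbers stand for higher lipophilicity and lower numbers for lower lipophilicity. Compound 2 and compound 1 share one core and differ in a single place: nitro in place of chloro on an aromatic carbon. That single swap gave a number 0.80 log units lower from compound 2 to compound 1 (beyond the scatter).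

Compound 3 rests on a different core; how its core differs from that of compound 2 is not broken down here. In this assay compound 3 gives 4.54, the highest of the three numbers.

Compound 4, `O=C(COc1cccc2ccccc12)N/N=C/c1ccccc1[N+](=O)[O-]`, has not yet been measured. It is related to compound 3 in the same way that compound 1 is related to compound 2: nitro in place of chloro on an aromatic carbon. The change is of the same kind, though not the same. In compound 1 the nitro sits para to a large group, whereas in compound 4 it sits ortho to a large group.

Among the compounds with values here, the only measured example of this swap gave a number 0.80 log units lower from compound 2 to compound 1 (beyond the scatter), and the expectation for compound 4 leans on it. A drop of about the same size is expected for compound 4, a number 0.79 log units lower from compound 3 to compound 4 (beyond the scatter). Within the data shown here, the place differs, and only one such step has been seen; the estimate carries extra room for doubt. Compound 4 is therefore estimated at 3.75 in this assay, most likely between 3.3 and 4.2.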

Compound 4, partition coefficient: 3.97
The estimate for compound 4 lay 0.22 log units below the measured number, within the range that was stated.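

In this assay the swap of nitro for chloro on an aromatic carbon has now been followed on two different cores, and it pushed the number the same way on both: the earlier pair gave a number 0.80 log units lower from compound 2 to compound 1 (beyond the scatter) and the new pair gave a number 0.57 log units lower from compound 3 to compound 4 (beyond the scatter) with the nitro ortho to a large group. So within this series the direction of the change carried over from one core to the other, even though the group sits at a different place in the two pairs, which makes the first step a useful guide to the second. Two pairs are still too few to show that the step keeps a fixed size or that it would hold on every core, and nothing available here explains why the number moves as it does.

The compounds shown leave open how a third core would respond to the same swap, and whether the same step appears when the group stands elsewhere on the ring of compound 3. They also leave open what other groups in that place, such as an amine or a carboxylic acid, would do to the number.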